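Iodo in Place of Bromo on a Shared Core

This account rests on a few compounds, and the source may have more. Where it says the series, first, only, none or still open, it means among the compounds named here.

Of the compounds shown here, two with the same core have been measured. In a functional assay on 1321-N1 cells for agonist activity at P2Y purinoceptor 6 (Homo sapiens), read by scintillation counting and inositol phosphate accumulation (on this read-out lower numbers stand for an effect already at smaller amounts and higher numbers for an effect only at larger amounts of compound), compound 1 `O=c1[nH]/c(=N\OCCCc2cccc(F)c2)ccn1[C@@H]1O[C@H](COP(=O)(O)OP(=O)(O)OP(=O)(O)O)[C@@H](O)[C@H]1O` gives 539 nM. Compound 2 `O=c1[nH]/c(=N\OCCCc2ccc(Br)cc2)ccn1[C@@H]1O[C@H](COP(=O)(O)OP(=O)(O)OP(=O)(O)O)[C@@H](O)[C@H]1O` gives 225 nM in this assay, the lowest of the two numbers, after a 2.4-fold lower number from compound 1 to compound 2 (0.38 log units; beyond the scatter). Compound 3 `O=c1[nH]/c(=N\OCCCc2ccc(I)cc2)ccn1[C@@H]1O[C@H](COP(=O)(O)OP(=O)(O)OP(=O)(O)O)[C@@H](O)[C@H]1O` differs from compound 2 by iodo in place of bromo on an aromatic carbon. For the measured compounds named here, the only measured step changes both the halogen and its place, so it guides this smaller change only weakly. For compound 3 a step of a 1.3-fold lower number from compound 2 to compound 3 (0.10 log units; within the scatter) is expected, small and close to the scatter. Compound 3 is estimated at 180 nM, within 70 nM to 450 nM.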

Compound 3, half-maximal effective concentration: 90 nM
Compound 3: the middle estimate sits 2.0-fold (0.30 log units) above what was measured; the range from low to high includes it.
By their numbers in this assay, from the lowest: compound 3; then compound 2; then compound 1.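

In this assay, the earlier step changed both the halogen and its place, whereas here the place stays the same and iodo in place of bromo alone gives a 2.5-fold lower number from compound 2 to compound 3 (0.40 log units; beyond the scatter) and so moves the number beyond the scatter. The 4-iodophenyl group in place of 3-fluorophenyl gives a 6.0-fold lower number from compound 1 to compound 3 (0.78 log units; beyond the scatter) as the widest gap so far. Nothing given here explains either step. As far as these compounds go, what chloro or an amine would do at this same place stays open, as does the effect of a longer chain.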